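The source may report more compounds than this note shows. Statements on the series, on what has been measured and on what is new or still open speak of the compounds shown alone.

Working notes on the series. The shared core is that of compound 1 `CC1CCN(C2CCN(S(=O)(=O)c3cccc(Br)c3)CC2)CC1`; compound 2 `CC1CCN(C2CCN(S(=O)(=O)c3ccc(C(C)(C)C)cc3)CC2)CC1` and compound 3 `CC1CCN(C2CCN(S(=O)(=O)c3cccc(-c4ccccc4F)c3)CC2)CC1` keep it and vary only the substituent on the aromatic carbon of the sulfonyl-bearing ring.

In an ADME assay on HCT-116 cells (Homo sapiens) for cytotoxicity, read by CellTiter-Glo, with a stated time of 72 h (on this read-out lower numbers stand for stronger inhibition and higher numbers for weaker inhibition), compound 1 gives > 5000 nM, which is a limit of the assay and not a number. Compound 2 gives > 5000 nM in this assay, likewise a limit. Compound 3 stands at > 5000 nM in this assay, again only a limit. Every value shown thus sits at the limit of > 5000 nM in this assay, at which 3 of the 3 values shown sit, and none of the three can be ordered against another. For the measured compounds named here, the single step between measured compounds that differ in one place, a step that the two limits leave unreadable from compound 1 to compound 3, is unreadable, both of its ends being limits.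

Compound 4 `Cc1ccc(-c2cccc(S(=O)(=O)N3CCC(N4CCC(C)CC4)CC3)c2)cc1` differs from compound 3 by 4-methylphenyl in place of 2-fluorophenyl on an aromatic carbon. Going by the values given here, no measured step bears on this change in a readable way: the only related step, from bromo to 2-fluorophenyl, gave no number, and no other pair separates a 4-methylphenyl from a 2-fluorophenyl. The expected step that the limit leaves unreadable from compound 3 to compound 4 is therefore none that can be resolved beyond the scatter, with the expectation that compound 4 will again be reported as a limit. Compound 4 is estimated at 8000 nM in this assay, with a range from 3000 nM to 30000 nM.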

Compound 4, half-maximal inhibitory concentration: > 5000 nM
Compound 4: a limit, no number; the forecaster's own chance of this, stated with the estimate: 85%; the middle value does not contradict the limit.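

No new step can be read from compound 4: its steps from compound 1 and from compound 3 each join two limits of the assay, so neither has a readable size. The compounds shown leave open whether any of these groups on the shared core gives a number in this assay, and how the groups would order, since every value stands at a single limit: the limit of > 5000 nM in this assay, at which 4 of the 4 values shown sit.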